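The compounds below may be only part of what the source reports. "The series", "measured", "known", "first", "only" and "open" are said of these compounds alone.

Working notes on the series.

Two compounds of the shared core have numbers in a functional assay on HepG2 cells (Homo sapiens) for cytotoxicity, read by MTT assay, with a stated time of 72 h; a lower number here means a stronger inhibitor, a higher number a weaker inhibitor. Compound 1 `CCN1CCN(CCC(=O)Nc2ccc3[nH]c(-c4ccc(Br)cc4)nc3c2)CC1` gives 27400 nM in this assay. Compound 2 `CCN1CCN(CCC(=O)Nc2ccc3[nH]c(-c4ccc(C)cc4)nc3c2)CC1` gives 14600 nM in this assay. Within the data shown here, the only measured step, a 1.9-fold lower number from compound 1 to compound 2 (0.27 log units; within the scatter), is the change of methyl in place of bromo on an aromatic carbon. Among the measured compounds shown here, compound 2 therefore holds the lowest of the two numbers, but its only neighbour, compound 1, sits within the scatter of it, so no ordering between the two is claimed.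

Compound 3 `CCN1CCN(CC(=O)Nc2ccc3[nH]c(-c4ccc(C)cc4)nc3c2)CC1` is not yet measured in this assay. It differs from compound 2 as follows: 4-ethylpiperazin-1-yl in place of (4-ethylpiperazin-1-yl)methyl on a saturated chain carbon bound to a carbonyl carbon. The chain between the amide carbonyl and the piperazine is shortened; the aryl substituent of compound 2 is kept. For the measured compounds named here, no measured step touches this part of the molecule, since a 1.9-fold lower number from compound 1 to compound 2 (0.27 log units; within the scatter) concerns the aromatic ring only, so nothing supports an expected shift in either direction beyond the scatter for this assay.

The step from compound 2 to compound 3 is therefore expected to be a 1.0-fold higher number from compound 2 to compound 3 (0.01 log units; within the scatter). Compound 3 is estimated at 15000 nM in this assay, with a range from 5000 nM to 45000 nM.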

Compound 3, half-maximal inhibitory concentration: 31900 nM
Compound 3: middle estimate off by 2.1-fold (0.33 log units), on the low side; measured number inside the range.
By their numbers in this assay, from the lowest: compounds 2, 1 and 3 (each within the scatter of the next, the first and the last beyond it).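

Among these compounds, the position on a saturated chain carbon bound to a carbonyl carbon gives the first step that lies beyond the scatter in this assay, with 4-ethylpiperazin-1-yl in place of (4-ethylpiperazin-1-yl)methyl giving a 2.2-fold higher number from compound 2 to compound 3 (0.34 log units; beyond the scatter) as a modest change towards a weaker inhibitor. Among the compounds shown here, the only earlier step, a 1.9-fold lower number from compound 1 to compound 2 (0.27 log units; within the scatter) on an aromatic carbon, stayed within the scatter, so the chain position is so far the only place where a single change can be read. No supporting data on the compounds bear on this step, and its origin stays unexplained.

Open, going by these compounds, is whether a longer chain would continue this trend or reverse it, and whether the step keeps its direction and size when bromo replaces methyl on the aromatic carbon. Also open, on these data alone, is how the number responds when a morpholine ring or a simple dimethylamine takes the place of 4-ethylpiperazin-1-yl on the chain, which would show whether the piperazine itself matters at this position.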